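Replacing a trifluoromethylphenyl ring with thiophene

The compounds below may be only part of what the source reports. "The series", "measured", "known", "first", "only" and "open" are said of these compounds alone.

Compound 1, `CCC(C)[C@H](N)c1cc(C(F)(F)F)ccc1N1CCN(C(=O)CCc2ccc(Cl)cc2)CC1`, gives 86 nM in an assay on HEK293 cells for displacement of a labelled ligand from Melanocortin receptor 4 (Homo sapiens); a lower number here means a stronger inhibitor, a higher number a weaker inhibitor.
Compound 2, `CCC(C)[C@H](N)c1cc(C(F)(F)F)ccc1N1CCN(C(=O)CCc2ccc(OC)cc2Cl)CC1`, gives 57 nM in this assay.
Compound 3, `CC(C)C[C@H](N)c1cc(C(F)(F)F)ccc1N1CCN(C(=O)CCc2cccc(C(F)(F)F)c2)CC1`, gives 2200 nM in this assay.

Compound 3 stands at the highest number of the three, and its gap to the other two lies beyond the scatter. Compound 1 and compound 2 share the same amine side chain and differ only in the aromatic group at the end of the amide tail; the step of a 1.5-fold lower number from compound 1 to compound 2 (0.18 log units; within the scatter) shows that this exchange of one aromatic ring for another at that position moved the number only within the scatter. Compound 3 differs from both of them in two places, so nothing can be said about which of its two differences accounts for its higher number.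

Compound 4, `CC(C)C[C@H](N)c1cc(C(F)(F)F)ccc1N1CCN(C(=O)CCc2cccs2)CC1`, keeps the whole of compound 3 except for one change: thiophen-2-yl in place of 3-(trifluoromethyl)phenyl on a saturated chain carbon, two bonds along the chain from a carbonyl carbon. For the measured compounds named here, the only measured step that bears on it is the one from compound 1 to compound 2, an exchange of aromatic groups at the same position that stayed within the scatter. On that basis the expected step from compound 3 to compound 4 in this assay is small, perhaps toward a slightly lower number, and may well stay within the scatter: a 1.5-fold lower number from compound 3 to compound 4 (0.17 log units; within the scatter). For compound 4 the estimated value is 1500 nM, with a range from 400 nM to 6000 nM.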

Compound 4, inhibition constant: 4600 nM
For compound 4 the middle estimate is 3.1-fold (0.49 log units) below the measured one; measured number inside the range.
By their numbers in this assay, from the lowest: compounds 2 and 1 (each within the scatter of the next); then compound 3; then compound 4.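

In this assay, thiophen-2-yl in place of 3-(trifluoromethyl)phenyl gives a 2.1-fold higher number from compound 3 to compound 4 (0.32 log units; beyond the scatter), so an exchange of aromatic groups on this saturated chain carbon, two bonds along the chain from a carbonyl carbon, can move the number beyond the scatter. The earlier exchange at the same position, a 1.5-fold lower number from compound 1 to compound 2 (0.18 log units; within the scatter), did not show this. The step is still modest for a change this large, in which a six-membered aromatic ring of carbon only, with 10 heavy atoms counting its trifluoromethyl group, gives way to a five-membered aromatic ring with 5 heavy atoms, but nothing measured here says why the number went up.

The change removes the trifluoromethyl group and swaps the ring at once, so the compounds shown cannot separate the two, and a plain phenyl ring at this position would be the natural way to pull them apart. From the compounds shown here alone, it also remains open whether thiophen-2-yl would give a step of similar size on the amine side chain of compound 1, or with a longer chain between the carbonyl and the ring.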